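The compounds below may be only part of what the source reports. "The series", "measured", "known", "first", "only" and "open" are said of these compounds alone.

The study measured three compounds in a functional assay on the whole organism (strain albino) for inhibition, with Rattus norvegicus as the target, read by paw edema, with stated times of 30 min and 3 h, at a dose of 100 mg/kg by the oral route (a higher number here means more inhibition at the dose given (going by the name of the read-out), a lower number less inhibition), and leaves a fourth to be estimated. Among the compounds with values here, compound 1 `COc1ccc(/C=C/C(=O)c2ccc(NC(=O)CBr)cc2)cc1` gives 46% in this assay, and compound 2 `COc1ccc(/C=C/C(=O)c2ccc(NC(=O)CO[N+](=O)[O-])cc2)cc1` gives 53%; the one measured step, a number 7 percentage points higher from compound 1 to compound 2 (within the scatter), concerns a change on the saturated chain. Compound 3 `CC(Br)C(=O)Nc1ccc(C(=O)/C=C/c2ccc(Cl)cc2)cc1` gives 59% in this assay, the largest of the three numbers, though compound 2 lies within the scatter of it and only compound 1 stands beyond the scatter below it.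

Compound 4 `COc1ccc(/C=C/C(=O)c2ccc(NC(=O)C(C)Br)cc2)cc1` differs from compound 3 by methoxy in place of chloro on an aromatic carbon. Within the data shown here, no measured step bears on this change: the only step recorded concerns the chain, not the aromatic ring. Compound 1, which carries the same methoxy group, gives 46%, while compound 3 with the chloro group gives 59%; the two also differ elsewhere, so nothing firm follows. The step of a number 7 percentage points lower from compound 3 to compound 4 (within the scatter) is therefore expected to stay within the scatter. Compound 4 is estimated at 52% in this assay, between 38% and 66%.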

Compound 4, a percentage reported as inhibition, in the whole organism at one dose (the size of the read-out at that dose, not a potency): 40%
The estimate for compound 4 lay 12 percentage points above the measured number; measured number inside the range.
By their numbers in this assay, from the lowest: compounds 4, 1, 2 and 3 (each within the scatter of the next, the first and the last beyond it).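

In this assay, within the data shown here, this is the first change at the aromatic carbon para to a large group that can be read in one place: going from 4-chlorophenyl to 4-methoxyphenyl gives a number 19 percentage points lower from compound 3 to compound 4 (beyond the scatter) and so matters more here than the chain changes seen so far. On the chain, methyl in place of hydrogen on the carbon bound to bromine gives a number 6 percentage points lower from compound 1 to compound 4 (within the scatter) and so adds no clear change, while 1-bromoethyl in place of (nitrooxy)methyl gives a number 13 percentage points lower from compound 2 to compound 4 (beyond the scatter) as a step beyond the scatter. No measurement shown here accounts for these steps.

Going by these compounds, whether the ring change would have the same size with the (nitrooxy)methyl chain stays open. So does how a fluoro group, an amine or a carboxylic acid at this ring position would read.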